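The source may hold more compounds than are shown below. What is called first, only, known or untested is meant among the compounds shown, and "the series" means these compounds.

Compound 3 `Nc1ccc(-c2cncc(Cl)n2)cc1` stands second highest of the three numbers measured in an assay on isolated protein for inhibition of high affinity nerve growth factor receptor (Homo sapiens), with a stated time of 60 min, tested at 20 uM; a lower number here means less inhibition, a higher number more inhibition at the concentration tested (going by the name of the read-out): compound 3 gives 47%, compound 2 `CC(C)(C)c1cc(NC(=O)Nc2ccc(-c3cncc(Cl)n3)cc2)on1` gives 41.4%, within the scatter of compound 3, and compound 1 `Nc1ccc(-c2cncc(-c3cncnc3)n2)cc1` gives 77%. Within the data shown here, the one measured step that bears on the next change is a number 30 percentage points lower from compound 1 to compound 3 (beyond the scatter), chloro in place of pyrimidin-5-yl on an aromatic carbon. Compound 4 `Nc1ccc(-c2cncc(-c3ccsc3)n2)cc1` runs that change the other way: thiophen-3-yl in place of chloro on an aromatic carbon. Because an aromatic ring on that carbon went with the higher number of compound 1 77%, a rise is expected, though thiophen-3-yl is not pyrimidin-5-yl and the size is uncertain. The expected step is a number 18 percentage points higher from compound 3 to compound 4 (beyond the scatter). Compound 4 is therefore estimated at 65%, with a range from 45% to 85%.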

Compound 4, a percentage reported as inhibition, at one concentration (the size of the read-out at that concentration, not a potency): 17%
Compound 4: middle estimate off by 48 percentage points, on the high side, outside the stated range (below it).
By their numbers in this assay, from the lowest: compound 4; then compounds 2 and 3 (each within the scatter of the next); then compound 1.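

Read in this assay this position shows a number 30 percentage points lower from compound 3 to compound 4 (beyond the scatter) and a number 60 percentage points lower from compound 1 to compound 4 (beyond the scatter) once thiophen-3-yl enters. An aromatic ring on this carbon therefore does not in itself go with the higher number: pyrimidin-5-yl stands above chloro, and thiophen-3-yl stands below it. No measurement on hand accounts for this split between the two rings.

Open, from the compounds shown here alone, is where a plain phenyl ring, a pyridin-3-yl ring or an amine on this carbon would fall. Also open, going by these compounds, is whether the order of the three groups would hold on the core of compound 2.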